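The source may hold more compounds than are shown below. What is called first, only, known or untested is meant among the compounds shown, and "the series" means these compounds.

Compound 1 `O=C(COc1ccc2cc(/C=C3/SC(=O)NC3=O)ccc2c1)Nc1ccccn1`: 17000 nM
Compound 2 `COc1ccc(NC(=O)COc2ccc3cc(/C=C4/SC(=O)NC4=O)ccc3c2)cc1`: 4700 nM

In an assay on isolated protein for inhibition of histone deacetylase 4 (Homo sapiens), with a stated time of 1 h (a higher number here means a weaker inhibitor, a lower number a stronger inhibitor), compound 2 holds the lower of the two numbers, since a 3.6-fold lower number from compound 1 to compound 2 (0.56 log units; beyond the scatter) lies beyond the scatter. Compound 3 `Cc1ccc(NC(=O)COc2ccc3cc(/C=C4/SC(=O)NC4=O)ccc3c2)cc1Cl` differs from compound 2 by 3-chloro-4-methylphenyl in place of 4-methoxyphenyl on an amide-type nitrogen. Within the data shown here, the only measured step at this nitrogen, a 3.6-fold lower number from compound 1 to compound 2 (0.56 log units; beyond the scatter), exchanged a different pair of groups, so it bears on the new change only loosely and gives no direction for it. Compound 3 is therefore expected to sit near compound 2, with a 1.2-fold lower number from compound 2 to compound 3 (0.07 log units; within the scatter) within or close to the scatter, at an estimated 4000 nM in this assay, between 1500 nM and 12000 nM.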

Compound 3, half-maximal inhibitory concentration: 1100 nM
Estimate against measurement, compound 3: 3.6-fold (0.56 log units) above, and the stated range ends above it.
By their numbers in this assay, from the lowest: compound 3; then compound 2; then compound 1.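

The exchange of 4-methoxyphenyl for 3-chloro-4-methylphenyl, with 8 heavy atoms in each group, gives a 4.3-fold lower number from compound 2 to compound 3 (0.63 log units; beyond the scatter) in this assay, so this nitrogen still responds when the ring stays carbon-only and only its substituents change. Across the three compounds, the position spans a 15-fold lower number from compound 1 to compound 3 (1.19 log units; beyond the scatter), a large step. Nothing available explains this difference. Going by these compounds, the chlorine and the methyl enter together, so their separate shares remain open. On these data alone, how a ring carrying an amine or a carboxylic acid would behave at this nitrogen also remains open.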